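This account rests on a few compounds, and the source may have more. Where it says the series, first, only, none or still open, it means among the compounds named here.

Measured compounds:
compound 1 `COC(=O)c1ccc(O)c(NC(=O)C(C)(C)Oc2ccc(C(C)(C)CC(C)(C)C)cc2)c1` — 11000 nM
compound 2 `COCCOc1ccc(C(=O)OC)cc1NC(=O)COc1ccc(C(C)(C)CC(C)(C)C)cc1` — 29000 nM

In an assay on isolated protein for inhibition of malate dehydrogenase, mitochondrial (Homo sapiens), with a stated time of 30 min (on this read-out higher numbers stand for weaker inhibition and lower numbers for stronger inhibition), compound 1 gives the lower of the two numbers, and compound 2 stands beyond the scatter above it. The unmeasured compound 3 `COC(=O)c1cccc(NC(=O)C(C)(C)Oc2ccc(C(C)(C)CC(C)(C)C)cc2)c1` is derived from compound 1 by one change: hydrogen in place of hydroxy on an aromatic carbon. Going by the values given here, no step of this kind has been measured here, so the size of its effect is not known from the data. Loss of a hydroxy group that carries a donor and an acceptor is expected to weaken inhibition modestly, giving a 1.8-fold higher number from compound 1 to compound 3 (0.26 log units; within the scatter). Compound 3 is therefore expected to give 20000 nM in this assay, within 6000 nM to 60000 nM.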

Compound 3, half-maximal inhibitory concentration: 1320 nM
Compound 3: the middle estimate sits 15-fold (1.18 log units) above what was measured; the measured number lies below the stated range.
By their numbers in this assay, from the lowest: compound 3; then compound 1; then compound 2.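

In this assay, hydrogen in place of hydroxy on the aromatic carbon para to a methoxycarbonyl group gives an 8.3-fold lower number from compound 1 to compound 3 (0.92 log units; beyond the scatter) and thus stronger inhibition. Inhibition at this position therefore does not depend on the hydroxy, and for this pair the unsubstituted carbon is clearly the better of the two. The data offer no measured basis for explaining this gain.

Open, as far as these compounds go, is whether a methoxy group, an amine or a fluorine at this carbon would match hydrogen or surpass it. Also open, from the compounds shown here alone, is whether the same replacement would have a similar effect in a compound with a different chain on the amide.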